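The compounds below may be only part of what the source reports. "The series", "measured", "known", "first", "only" and "open" are said of these compounds alone.

Compound 1 `COc1ccc2ncc(S(=O)(=O)c3ccc(C)c(Cl)c3)c(N3CCC(C)CC3)c2c1`: 85%
Compound 2 `Cc1cc(C)cc(S(=O)(=O)c2cnc3cc(F)ccc3c2N2CCC(C)CC2)c1`: 80%

In an assay on isolated protein for displacement of a labelled ligand from metabotropic glutamate receptor 5 (Homo sapiens), with a stated time of 60 min, tested at 1 uM (on this read-out lower numbers stand for less inhibition and higher numbers for more inhibition at the one concentration tested (going by the name of the read-out)), compound 1 gives 85% and compound 2 gives 80%; compound 2 shows the smaller of the two numbers, but only by a gap within the scatter, so the two read as alike. Compound 3 `Cc1ccc(S(=O)(=O)c2cnc3cc(F)ccc3c2N2CCC(C)CC2)cc1Cl` has not yet been measured. It differs from compound 2 in one place: 3-chloro-4-methylphenyl in place of 3,5-dimethylphenyl on a sulfonyl sulfur. Compound 1, which gives 85%, already carries the 3-chloro-4-methylphenyl group on its sulfonyl sulfur and sits within the scatter of compound 2, so the expected step is a number 2 percentage points higher from compound 2 to compound 3 (within the scatter), nothing beyond the scatter. Compound 3 is therefore expected to give 82%, between 65% and 93%.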

Compound 3, a percentage reported as inhibition, at one concentration (the size of the read-out at that concentration, not a potency): 93%
Compound 3: middle estimate off by 11 percentage points, on the low side, and the stated range covers the measured number.
By their numbers in this assay, from the lowest: compounds 2, 1 and 3 (each within the scatter of the next, the first and the last beyond it).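

Among these compounds, the step with this assay is the first comparison that changes one place only: 3-chloro-4-methylphenyl in place of 3,5-dimethylphenyl on a sulfonyl sulfur gives a number 13 percentage points higher from compound 2 to compound 3 (beyond the scatter). So the aryl group on this sulfur affects the read-out, although the two groups match in heavy atoms and in hydrogen-bond donors and acceptors. No measurement here explains the step. As far as these compounds go, whether the chlorine or the altered methyl pattern carries it stays open. From the compounds shown here alone, a plain phenyl or a 4-trifluoromethylphenyl group on this sulfur also remains untested in these compounds.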